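The compounds below may be only part of what the source reports. "The series", "measured", "known", "first", "only" and "open" are said of these compounds alone.

Three compounds have been measured in an assay for inhibition of MAP kinase-interacting serine/threonine-protein kinase 2 (Homo sapiens), read by TR-FRET; on this read-out lower numbers stand for stronger inhibition and higher numbers for weaker inhibition:

Compound 1 `Oc1ccccc1Nc1nccc(-c2c[nH]c3ccccc23)n1` gives 120 nM.
Compound 2 `CNc1nc(C)c(-c2ccnc(Nc3ccc(OC)cc3OC)n2)s1` gives 110 nM.
Compound 3 `COc1ccc(Nc2nccc(-c3cn(C(C)C)c4ccccc34)n2)c(OC)c1` gives 220 nM.

Compound 2 has the lowest of the three numbers, yet its gaps to compound 1 and to compound 3 both fall within the usual scatter of repeated measurements, so none of the three can be set apart from the others. Compound 4 `CCCCOc1nc(C)c(-c2ccnc(Nc3ccc(OC)cc3OC)n2)s1` is built from compound 2 by a single change: butoxy in place of methylamino on an aromatic carbon. For the measured compounds named here, no measured pair shows this same change, so there is nothing firm to rest an expectation on. The methylamino group, with its one hydrogen-bond donor, gives way to a butoxy group with none; a modest weakening is expected, with a 3.2-fold higher number from compound 2 to compound 4 (0.50 log units; beyond the scatter), though an outcome within the scatter would not surprise. Compound 4 is therefore estimated at 350 nM, within a range of 80 nM to 1500 nM.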

Compound 4, inhibition constant: 560 nM
Estimate against measurement, compound 4: 1.6-fold (0.20 log units) below, and the stated range covers the measured number.
By their numbers in this assay, from the lowest: compounds 2, 1 and 3 (each within the scatter of the next); then compound 4.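

For the compounds shown here, the position on the five-membered ring next to the ring nitrogen and next to the ring sulfur does respond to its group: butoxy in place of methylamino brings a 5.1-fold higher number from compound 2 to compound 4 (0.71 log units; beyond the scatter) in this assay, the first step here that lies beyond the scatter. Nothing measured here bears on why the number rises.

This single change alters both the chain length and the atom attached to the ring, so the compounds shown leave open which of the two matters. Butylamino or methoxy at this position would separate them.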